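Replacing the 4-cyanophenyl group of compound 3

This account rests on a few compounds, and the source may have more. Where it says the series, first, only, none or still open, it means among the compounds named here.

In a physicochemical assay for lipophilicity, measured as octanol-water partition (a higher number here means a more lipophilic compound, a lower number a more polar compound), compound 1 `O=C(NNc1ccnc2cc(Cl)ccc12)c1ccccc1/N=C/c1cccc(Cl)c1Cl` gives 6.1, compound 2 `COc1ccc(/C=N/c2ccccc2C(=O)NNc2ccnc3cc(Cl)ccc23)cc1` gives 5 and compound 3 `N#Cc1ccc(/C=N/c2ccccc2C(=O)NNc2ccnc3cc(Cl)ccc23)cc1` gives 4.83. Compound 3 therefore sits with compound 2, well under compound 1. Compound 4 `O=C(NNc1ccnc2cc(Cl)ccc12)c1ccccc1/N=C/c1cc2ccccc2[nH]c1=O` differs from compound 3 in one place: a group of 11 heavy atoms (9 carbon, 1 nitrogen, 1 oxygen; one six-membered aromatic ring of carbon only, one six-membered aromatic ring with 1 hetero atom) in place of a group of 8 heavy atoms (7 carbon, 1 nitrogen; one six-membered aromatic ring of carbon only), on a carbon with a double bond to nitrogen. The entering group has more heavy atoms and also a hydrogen-bond donor, which 4-cyanophenyl lacks. Among the measured compounds shown here, three measured steps bear on this place: a number 1.10 log units lower from compound 1 to compound 2 (beyond the scatter), a number 1.27 log units lower from compound 1 to compound 3 (beyond the scatter) and a number 0.17 log units lower from compound 2 to compound 3 (within the scatter). None of them brings in a group like this one, so they offer only rough guidance. In this assay, a small upward step is expected, a number 0.17 log units higher from compound 3 to compound 4 (within the scatter). The estimate for compound 4 is 5, with an expected range from 4.4 to 5.6.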

Compound 4, partition coefficient: 4.65
Compound 4: middle estimate off by 0.35 log units, on the high side; the measured number falls inside the stated range.
By their numbers in this assay, from the lowest: compounds 4, 3 and 2 (each within the scatter of the next, the first and the last beyond it); then compound 1.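

In this assay, the group of 11 heavy atoms with its hydrogen-bond donor gives a number 0.18 log units lower from compound 3 to compound 4 (within the scatter) and so cannot be told apart from 4-cyanophenyl. It also gives a number 0.35 log units lower from compound 2 to compound 4 (beyond the scatter) and a number 1.45 log units lower from compound 1 to compound 4 (beyond the scatter), so on this carbon the extra heavy atoms of compound 4 bring no rise over any earlier compound. Nothing measured here accounts for these numbers. Still open, going by these compounds, is how a phenyl group carrying an amine or a carboxylic acid would read on this carbon, and whether either would fall beyond the scatter from compound 4.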